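The compounds below may be only part of what the source reports. "The series", "measured", "known", "first", "only" and "open" are said of these compounds alone.

In a functional assay on HT-29 cells (Homo sapiens) for antiproliferative activity, read by sulforhodamine B assay, with a stated time of 48 h (on this read-out higher numbers stand for weaker inhibition and lower numbers for stronger inhibition), compound 1 (`Cc1ccc(C)c(NS(=O)(=O)c2ccc(N3CCNC3=O)cc2)c1`) gives 46 nM, and compound 2 (`Cc1ccc(NS(=O)(=O)c2ccc(N3CCNC3=O)cc2)c(C)c1`) gives 180 nM, the higher of the two numbers. Compound 3 (`COc1ccc(NS(=O)(=O)c2ccc(N3CCNC3=O)cc2)cc1`) carries 4-methoxyphenyl in place of 2,4-dimethylphenyl on a sulfonamide nitrogen. Within the data shown here, the one measured step bearing on this change is a 3.9-fold higher number from compound 1 to compound 2 (0.59 log units; beyond the scatter), which alters the same group. Among the measured compounds shown here, no measured compound holds a methoxy group, so the direction is uncertain. A modest step towards a higher number is expected in this assay. The estimated step is a 2.8-fold higher number from compound 2 to compound 3 (0.44 log units; beyond the scatter). For compound 3, the estimated value is 500 nM, with an expected range of 130 nM to 2500 nM.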

Compound 3, half-maximal inhibitory concentration: 800 nM
Estimate against measurement, compound 3: 1.6-fold (0.20 log units) below; low and high end bracket the measured number.
By their numbers in this assay, from the lowest: compound 1; then compound 2; then compound 3.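

Moving to 4-methoxyphenyl on the sulfonamide nitrogen gives a 4.4-fold higher number from compound 2 to compound 3 (0.65 log units; beyond the scatter) in this assay, and the same group against 2,5-dimethylphenyl gives a 17-fold higher number from compound 1 to compound 3 (1.24 log units; beyond the scatter). Among these compounds, the aryl group at this position thus moves the number over a large span, and the one methoxy-bearing group sits at the high end of the three. Nothing available accounts for this rise.

On these data alone, the change removes two methyl groups and adds a methoxy group in one step, so the share of each stays open. Unsubstituted phenyl, or an amine in place of the methoxy group, would separate these contributions.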